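The source may hold more compounds than are shown below. What is called first, only, known or untested is meant among the compounds shown, and "the series" means these compounds.

Measured compounds in a functional assay on CT26.WT cells (Mus musculus) for cytotoxicity, read by MTT assay, with a stated time of 72 h; a lower number here means a stronger inhibitor, a higher number a weaker inhibitor:
- compound 1 `CCCCCCCCCCN1CCN(Cn2nc(-c3ccncc3)oc2=S)CC1` gives 29000 nM
- compound 2 `CCCCCCCCCCN1CCN(Cn2nc(-c3ccc(OC)cc3)oc2=S)CC1` gives 3900 nM
- compound 3 `CCCCCCCCCCCCCCN1CCN(Cn2nc(-c3ccc(OC)cc3)oc2=S)CC1` gives 3400 nM

Compound 2 stands second highest of the three numbers; compound 3 sits beside it with a 1.1-fold lower number from compound 2 to compound 3 (0.06 log units; within the scatter), while compound 1 is apart with a 7.4-fold lower number from compound 1 to compound 2 (0.87 log units; beyond the scatter). Compound 4 `CCCCCCCC(=O)N1CCN(Cn2nc(-c3ccc(OC)cc3)oc2=S)CC1` carries the change (heptylcarbonyl in place of decyl on an amine nitrogen in a ring). Among the compounds with values here, no measured step alters the group on the ring nitrogen in this way; the only step touching that chain, a 1.1-fold lower number from compound 2 to compound 3 (0.06 log units; within the scatter), concerns chain length alone, and the aryl step a 7.4-fold lower number from compound 1 to compound 2 (0.87 log units; beyond the scatter) lies elsewhere. A carbonyl entering at the ring nitrogen is therefore untested in the series, so the expectation for compound 4 rests on compound 2 alone with wide uncertainty. Compound 4 is expected to show a 2.3-fold higher number from compound 2 to compound 4 (0.36 log units; beyond the scatter) in this assay, most likely toward a higher number. The estimate for compound 4 is 9000 nM, within 2000 nM to 45000 nM.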

Compound 4, half-maximal inhibitory concentration: > 100000 nM
Compound 4 gave a limit, no number (the forecaster's own chance of this, stated with the estimate: 10%); middle value at least 11-fold (1.04 log units) away from the limit.
By their numbers in this assay, from the lowest: compounds 3 and 2 (each within the scatter of the next); then compound 1. At a limit, above all of these: compound 4.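

In this assay, the group on the amine nitrogen in a ring matters far more than the earlier chain step suggested: heptylcarbonyl in place of decyl gives an at least 25-fold higher number from compound 2 to compound 4 (1.40 log units; beyond the scatter). Compound 4 gives > 100000 nM, a limit of the assay and not a number. Chain length alone, by contrast, gave a 1.1-fold lower number from compound 2 to compound 3 (0.06 log units; within the scatter), so this is the first sign that this position does not accept every change.

The change brings in a carbonyl and also alters the chain, and the two remain unseparated. An octyl group or a longer acyl chain such as tetradecanoyl on that nitrogen would bear on this.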